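This account rests on a few compounds, and the source may have more. Where it says the series, first, only, none or still open, it means among the compounds named here.

In an ADME assay on MT4 cells (Homo sapiens) for cytotoxicity, read by MTT assay, with a stated time of 5 days (on this read-out lower numbers stand for higher toxicity in this test and higher numbers for lower toxicity in this test), compound 1 (`N#Cc1ccc(Nc2nccc(C(O)c3ccc(-c4ccc(C#N)cc4)cc3Cl)n2)cc1`) gives 7540 nM and compound 2 (`N#Cc1ccc(Nc2nccc([C@H](O)c3ccc(-c4ccc(C#N)cc4)cc3Cl)n2)cc1`) gives 28100 nM, the higher of the two numbers. Among the measured compounds shown here, the one measured step is a 3.7-fold higher number from compound 1 to compound 2 (0.57 log units; beyond the scatter), and it lies beyond the scatter. What separates the pair is the fact that one of compounds 1 and 2 is drawn with a defined configuration and the other without, at the place where they differ. Compound 3 (`N#Cc1ccc(Nc2nccc([C@H](O)c3ccc(-c4ccc(C#N)cc4)cc3C(F)(F)F)n2)cc1`) keeps the drawn configuration of compound 2 and carries trifluoromethyl in place of chloro on an aromatic carbon. The measured step does not touch this group, as compound 1 and compound 2 both carry chloro, so the size of a 3.7-fold higher number from compound 1 to compound 2 (0.57 log units; beyond the scatter) is no direct guide to the new change. No step beyond the scatter is therefore expected, and the estimated change is a 1.3-fold lower number from compound 2 to compound 3 (0.11 log units; within the scatter). For compound 3 the expected value is 22000 nM, with an estimated range from 8000 nM to 60000 nM.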

Compound 3, half-maximal cytotoxic concentration: 24100 nM
For compound 3 the middle estimate is 1.1-fold (0.04 log units) below the measured one, within the range that was stated.
By their numbers in this assay, from the lowest: compound 1; then compounds 3 and 2 (each within the scatter of the next).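

In this assay, the aromatic carbon ortho to a large group and meta to a 4-cyanophenyl group takes trifluoromethyl in place of chloro, 4 heavy atoms entering where 1 leaves, and the result is a 1.2-fold lower number from compound 2 to compound 3 (0.07 log units; within the scatter). This position, untouched by the earlier step, therefore shows no change beyond the scatter on this swap, with the drawn configuration held constant. Nothing measured here accounts for this result.

The compounds shown speak for chloro and trifluoromethyl alone at this position, so it stays open whether a methoxy group, an amine or a carboxylic acid there would leave the number equally undisturbed. Also open, from the compounds shown here alone, is whether the gap seen with chloro between the drawn and undrawn configuration carries over to trifluoromethyl.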